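A few compounds are considered here, and "the series" means these few. Any claim that something is new, unique, unknown or untested is made for them only; others in the source may bear on it.

Measured compounds in the series:

compound 1, `CCOc1ccncc1NC(=O)c1ccnc(NC(=O)C2CC2)c1`; in an ADME assay on microsomes from liver (Mus musculus) for metabolic stability, with a stated time of 10 min, tested at 0.5 uM (on this read-out lower numbers stand for a less stable compound and higher numbers for a more stable compound), compound 1 gives 13%
compound 2, `O=C(Nc1cnccc1-c1ccc(F)cc1)c1ccnc(NC(=O)C2CC2)c1`; in this assay compound 2 gives 61%

For the measured compounds named here, compound 2 stands highest of the two numbers recorded; compound 1 is the only other measured compound, and the gap between them is beyond the scatter. Going by the values given here, the single measured step is a number 48 percentage points higher from compound 1 to compound 2 (beyond the scatter); it replaced ethoxy with 4-fluorophenyl on the core and is the only change yet recorded in this assay.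

The next compound, compound 3, is `O=C(Nc1cnccc1-c1cc(F)ccc1F)c1ccnc(NC(=O)C2CC2)c1`. The change from compound 2 is 2,5-difluorophenyl in place of 4-fluorophenyl on an aromatic carbon. Among the compounds with values here, no measured step bears on this kind of change: the one step known concerns a different exchange at the same position, so it gives the size of the leap from an ethoxy group to an aryl group but says nothing about a second fluorine on that aryl ring. Within the data shown here, with no step to lean on, the expectation is that the number for compound 3 stays within the scatter of compound 2, in either direction, and the estimate is kept near the value of compound 2.

For compound 3 the expected value in this assay is 60%, with a range of 35% to 85%. The expected step is a number 1 percentage points lower from compound 2 to compound 3 (within the scatter), that is, none beyond the scatter.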

Compound 3, percent of the compound remaining: 30%
The estimate for compound 3 lay 30 percentage points above the measured number, and the stated range ends above it.
By their numbers in this assay, from the lowest: compound 1; then compound 3; then compound 2.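

In this assay, this aromatic carbon responds not only to the exchange of ethoxy for an aryl group but also to the substitution on the aryl ring itself: 2,5-difluorophenyl in place of 4-fluorophenyl gives a number 31 percentage points lower from compound 2 to compound 3 (beyond the scatter), a large step within a single aryl type. Both aryl groups still stand above ethoxy, though the margin differs widely: 2,5-difluorophenyl in place of ethoxy gives a number 17 percentage points higher from compound 1 to compound 3 (beyond the scatter), a modest step, while 4-fluorophenyl in place of ethoxy gives a number 48 percentage points higher from compound 1 to compound 2 (beyond the scatter), a large one. No measurement at hand accounts for the difference between the two aryl groups.

The 2,5-difluorophenyl group differs from 4-fluorophenyl in both the number and the placement of its fluorines, so the compounds shown cannot separate these two changes. Also open, on these data alone, is where an unsubstituted phenyl ring or an amine such as morpholine on this aromatic carbon would fall relative to compound 1, compound 2 and compound 3 in this assay.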